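The source may hold more compounds than are shown below. What is called first, only, known or untested is meant among the compounds shown, and "the series" means these compounds.

Measured so far in a functional assay on MCF7 cells (Homo sapiens) for antiproliferative activity, read by MTT assay, with a stated time of 48 h; on this read-out higher numbers stand for weaker inhibition and lower numbers for stronger inhibition:
compound 1 `CC(C)=CCC[C@]1(C)/C=C/[C@@H](OC(=O)C=C(C)C)[C@](C)(O)/C=C/C(=O)/C(CN2CCCC2)=C\C1`: 220 nM
compound 2 `CC[Si](CC)(CC)C/C1=C/C[C@](C)(CCC=C(C)C)/C=C/[C@@H](OC(=O)C=C(C)C)[C@](C)(O)/C=C/C1=O`: 3150 nM
compound 3 `CC(C)=CCC[C@]1(C)/C=C/[C@@H](OC(=O)C=C(C)C)[C@](C)(O)/C=C/C(=O)/C(Cn2cc(CO)nn2)=C\C1`: 2930 nM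

Compound 3 holds the second highest of the three numbers, within the scatter of compound 2 and well above compound 1. Compound 4 `CC(C)=CCC[C@]1(C)/C=C/[C@@H](OC(=O)C=C(C)C)[C@](C)(O)/C=C/C(=O)/C(C(=O)N2CCCC2)=C\C1` carries (pyrrolidin-1-yl)carbonyl in place of (4-(hydroxymethyl)-1H-1,2,3-triazol-1-yl)methyl on a double-bonded ring carbon. The nearest evidence is mixed. The large steps of a 14-fold higher number from compound 1 to compound 2 (1.16 log units; beyond the scatter) and a 13-fold higher number from compound 1 to compound 3 (1.12 log units; beyond the scatter) show that only compound 1, at 220 nM, has the low number, while a 1.1-fold lower number from compound 2 to compound 3 (0.03 log units; within the scatter) lies within the scatter. Within the data shown here, compound 4 shares the five-membered non-aromatic ring of compound 1, but no measured compound has the carbonyl link. In this assay, no step beyond the scatter is therefore expected, though a lower number remains possible. The expected step is a 1.2-fold lower number from compound 3 to compound 4 (0.07 log units; within the scatter). Compound 4 is estimated at 2500 nM, with an expected range of 800 nM to 8000 nM.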

Compound 4, half-maximal inhibitory concentration: 17200 nM
Beside the measured number, compound 4's estimate is 6.9-fold (0.84 log units) below it, outside the stated range (above it).
By their numbers in this assay, from the lowest: compound 1; then compounds 3 and 2 (each within the scatter of the next); then compound 4.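

In this assay the link that joins the pyrrolidine ring to this double-bonded ring carbon matters: (pyrrolidin-1-yl)carbonyl in place of (pyrrolidin-1-yl)methyl gives a 78-fold higher number from compound 1 to compound 4 (1.89 log units; beyond the scatter) and so the five-membered non-aromatic ring alone does not carry the low number. Compound 2 and compound 3 also did not mark the upper end at this position, as shown by a 5.9-fold higher number from compound 3 to compound 4 (0.77 log units; beyond the scatter) and by a 5.5-fold higher number from compound 2 to compound 4 (0.74 log units; beyond the scatter) in the same assay. Nothing available here accounts for these steps.
On these data alone, whether another amine on the methyl link, such as (piperidin-1-yl)methyl or (dimethylamino)methyl, would keep the low number of compound 1 stays open. So does whether an open-chain amide such as (diethylamino)carbonyl would match compound 4.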